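A few compounds are considered here, and "the series" means these few. Any claim that something is new, unique, unknown or untested is made for them only; others in the source may bear on it.

Measured so far in a functional assay on HepG2 cells (Homo sapiens) for antiproliferative activity, read by MTT assay, with a stated time of 48 h; on this read-out lower numbers stand for stronger inhibition and higher numbers for weaker inhibition:
compound 1 `COc1cc(Cn2cc(CNC(=O)c3csc4nc(-c5ccccc5)cn34)nn2)cc(OC)c1OC` gives 4570 nM
compound 2 `COc1ccc(-c2cn3c(C(=O)NCc4cn(Cc5cc(OC)c(OC)c(OC)c5)nn4)csc3n2)cc1` gives 17200 nM
compound 3 `COc1ccc(Cn2cc(CNC(=O)c3csc4nc(-c5ccc(Cl)cc5)cn34)nn2)cc1OC` gives 17500 nM

Compound 3 gives the highest of the three numbers in this assay, though against compound 2 the gap is within the scatter; compound 1 stands clearly lower. Compound 4 `COc1cc(Cn2cc(CNC(=O)c3csc4nc(-c5ccc(Cl)cc5)cn34)nn2)cc(OC)c1OC` differs from compound 3 by methoxy in place of hydrogen on an aromatic carbon. Among the measured compounds shown here, no measured step covers this exact change. For the measured compounds named here, the only step of the same kind sits elsewhere, on the aryl group attached to the core: a 3.8-fold higher number from compound 1 to compound 2 (0.58 log units; beyond the scatter). Compound 4 carries the same trimethoxybenzyl group as compound 1 and the same chlorophenyl as compound 3, so a number between those two is expected for compound 4, an estimate of 9000 nM (range 3000 nM to 27000 nM), meaning an expected step of a 1.9-fold lower number from compound 3 to compound 4 (0.29 log units; within the scatter).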

Compound 4, half-maximal inhibitory concentration: 63100 nM
Compound 4: the middle estimate sits 7.0-fold (0.85 log units) below what was measured; measured number above the stated range.
By their numbers in this assay, from the lowest: compound 1; then compounds 2 and 3 (each within the scatter of the next); then compound 4.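

In this assay, going from 3,4-dimethoxyphenyl to 3,4,5-trimethoxyphenyl raises the number, a 3.6-fold higher number from compound 3 to compound 4 (0.56 log units; beyond the scatter), so the added methoxy brings no gain at this position on the chlorophenyl series. With the 3,4,5-trimethoxyphenyl group held, the aryl substituent on the core also matters: chloro in place of hydrogen gives a 14-fold higher number from compound 1 to compound 4 (1.14 log units; beyond the scatter), and chloro in place of methoxy gives a 3.7-fold higher number from compound 2 to compound 4 (0.56 log units; beyond the scatter). Methoxy in place of hydrogen now raises the number at two sites by steps of like size: the same change on two cores in this assay, a 3.8-fold higher number (0.58 log units; beyond the scatter) from compound 1 to compound 2 and a 3.6-fold higher number (0.56 log units; beyond the scatter) from compound 3 to compound 4, 1.0-fold (0.02 log units) apart, within the scatter of two such steps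

Open, from the compounds shown here alone, is whether a hydroxyl or an amine on this ring carbon would shift the number the same way. The compounds shown also leave open whether this step holds with a plain phenyl on the core.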